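Swapping methoxy for fluoro on a weakly cytotoxic amide

The source may hold more compounds than are shown below. What is called first, only, known or untested is meant among the compounds shown, and "the series" means these compounds.

Of the compounds shown here, two sharing one core have been tested in a functional assay on QGY7701 cells (Homo sapiens) for cytotoxicity, read by MTT assay, with a stated time of 24 h; on this read-out lower numbers stand for stronger inhibition and higher numbers for weaker inhibition. Compound 1 `C=CC1=C(C(=O)NCc2ccccc2F)C(c2ccc(F)cc2)OC1` gives 51400 nM in this assay. Compound 2 `C=CC1=C(C(=O)Nc2ccccc2)C(c2ccc(OC)cc2)OC1` returns only a limit of this assay, reported as > 100000 nM. This is the limit of > 100000 nM in this assay, at which 1 of the 2 values shown sits. Compound 3 `C=CC1=C(C(=O)Nc2ccccc2)C(c2ccc(F)cc2)OC1` is the next compound to be measured. It differs from compound 2 in one place: fluoro in place of methoxy on an aromatic carbon. For the measured compounds named here, no pair of measured compounds differs by exactly this change, so no measured step can serve as a direct guide. As compound 2 sits at the limit, the step to compound 3 could be anything from no change beyond the scatter to a modest gain. The expected value for compound 3 in this assay is 80000 nM, within a range from 30000 nM to 200000 nM. This amounts to an expected step of an at least 1.2-fold lower number from compound 2 to compound 3 (0.09 log units; that floor lies within the scatter), with a fair chance that compound 3 also returns only a limit.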

Compound 3, half-maximal inhibitory concentration: 46700 nM
The estimate for compound 3 lay 1.7-fold (0.23 log units) above the measured number, within the range that was stated.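

In this assay, changing 4-methoxyphenyl to 4-fluorophenyl brings an at least 2.1-fold lower number from compound 2 to compound 3 (0.33 log units; beyond the scatter) and so shows that this position responds to the group it carries. On these data alone, that step has only a floor and its full size stays unknown, since one end of it is a limit: the limit of > 100000 nM in this assay, at which 1 of the 3 values shown sits. With the 4-fluorophenyl group in place, phenyl in place of 2-fluorobenzyl on the amide-type nitrogen brings a 1.1-fold lower number from compound 1 to compound 3 (0.04 log units; within the scatter) and so shows no real change from that swap.

As far as these compounds go, how a chloro, a hydroxyl or an amine on this aromatic carbon would compare with fluoro remains open. From the compounds shown here alone, it is also open whether changing 4-methoxyphenyl to 4-fluorophenyl gives a similar step when 2-fluorobenzyl sits on the nitrogen.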